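The source may hold more compounds than are shown below. What is called first, only, known or untested is meant among the compounds shown, and "the series" means these compounds.

In a functional assay on KB cells (Homo sapiens) for inhibition, with a stated time of 72 h (a lower number here means a stronger inhibitor, a higher number a weaker inhibitor), compound 1 `COc1ccc(S(=O)(=O)N2CCc3cccc(-c4ccc(F)nc4)c32)cc1` gives 143 nM, the lowest of the two numbers seen so far. Compound 2 `COc1ccc(S(=O)(=O)N2CCc3cccc(-c4cc(OC)c(OC)c(OC)c4)c32)cc1` gives 3690 nM in this assay, a gap beyond the usual scatter. Compound 3 `COc1ccc(S(=O)(=O)N2CCc3cccc(-c4cccs4)c32)cc1` has not yet been measured. It differs from compound 1 in one place: thiophen-2-yl in place of 6-fluoropyridin-3-yl on an aromatic carbon. Among the compounds with values here, no measured pair shows this change, so the step is expected to be modest, toward a somewhat higher number, with a step of a 2.1-fold higher number from compound 1 to compound 3 (0.32 log units; beyond the scatter) in this assay. Compound 3 is estimated at 300 nM, within a range from 80 nM to 1500 nM.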

Compound 3, half-maximal inhibitory concentration: 215 nM
Beside the measured number, compound 3's estimate is 1.4-fold (0.14 log units) above it; measured number inside the range.
By their numbers in this assay, from the lowest: compounds 1 and 3 (each within the scatter of the next); then compound 2.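

In this assay, replacing 6-fluoropyridin-3-yl with thiophen-2-yl gives a step of a 1.5-fold higher number from compound 1 to compound 3 (0.18 log units; within the scatter). This position on the aromatic carbon therefore tolerates a five-membered aromatic ring with sulfur as well as a six-membered one with nitrogen, and the fluorine is not needed for a number in this range. No measurement offers a reason for this result.

Going by these compounds, whether this position needs an aromatic ring at all remains open. A plain amine or a short alkyl chain such as ethyl there could answer that.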